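The source may hold more compounds than are shown below. What is called first, only, known or untested is meant among the compounds shown, and "the series" means these compounds.

In a functional assay for inhibition, with Homo sapiens as the target (a higher number here means a weaker inhibitor, a lower number a stronger inhibitor), the values are as follows:
Compound 1 `O=C(NC[C@H](NS(=O)(=O)c1ccccc1)C(=O)O)c1cc2cc(OCC3CCNCC3)ccc2[nH]1`: 13 nM
Compound 2 `O=C(NC[C@H](NS(=O)(=O)c1ccccc1)C(=O)O)c1cc2cc(OCCC3CCNCC3)ccc2[nH]1`: 8 nM
Compound 3 `O=C(NC[C@H](NS(=O)(=O)c1ccccc1)C(=O)O)c1cc2cc(OCc3ccncc3)ccc2[nH]1`: 280 nM

Compound 1 sits at the low end of these numbers: its nearest neighbour lies at a 1.6-fold lower number from compound 1 to compound 2 (0.21 log units; within the scatter) and its furthest at a 22-fold higher number from compound 1 to compound 3 (1.33 log units; beyond the scatter) in the same series. Within the data shown here, compound 4 `O=C(O)CCNC(=O)c1cc2cc(OCC3CCNCC3)ccc2[nH]1` departs from compound 1 by hydrogen in place of (phenylsulfonyl)amino on a saturated chain carbon bound to a carbonyl carbon and a saturated chain carbon with hydrogen in place of (phenylsulfonyl)amino, at a place that no measured compound varies. Among the measured compounds shown here, all the measured steps concern the group on the saturated chain carbon bound to an oxygen on an aromatic ring, so they bear on this change only indirectly. They show that a single change here can stay small or reach a 35-fold higher number from compound 2 to compound 3 (1.54 log units; beyond the scatter) in size. From the compounds shown here alone, a step to a higher number, beyond the scatter, is therefore expected in this assay but remains untested. The expected step is an estimated 13-fold higher number from compound 1 to compound 4 (1.12 log units; beyond the scatter) with wide uncertainty. Compound 4 is estimated at 170 nM within an expected range of 40 nM to 700 nM at this stage.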

Compound 4, half-maximal inhibitory concentration: 1000 nM
Beside the measured number, compound 4's estimate is 5.9-fold (0.77 log units) below it, and the stated range ends below it.
By their numbers in this assay, from the lowest: compounds 2 and 1 (each within the scatter of the next); then compound 3; then compound 4.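

In this assay, taking the (phenylsulfonyl)amino group off the saturated chain carbon bound to a carbonyl carbon and a saturated chain carbon, with the rest of compound 1 unchanged, gives a 77-fold higher number from compound 1 to compound 4 (1.89 log units; beyond the scatter). The earlier compounds shown here varied only the group on the saturated chain carbon bound to an oxygen on an aromatic ring, whereas this step shows that the value also depends on what stands at this second position. No data given here account for the step.

The change removes the whole group at once, so the compounds shown leave open how much of the step belongs to the phenyl ring, the sulfonyl or the nitrogen. A plain amine or an acetylamino group at this carbon would bear directly on that question.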